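A few compounds are considered here, and "the series" means these few. Any claim that something is new, unique, unknown or untested is made for them only; others in the source may bear on it.

Compounds measured so far:
- compound 1, `CN(c1cc2ncc(=O)[nH]c2cc1NC(=N)NCc1ccc(F)cc1)C1CCCCC1`, in an ADME assay on Huh-7 cells (Homo sapiens) for cytotoxicity (on this read-out higher numbers stand for weaker inhibition and lower numbers for stronger inhibition), compound 1 gives 10200 nM
- compound 2, `CN(c1cc2ncc(=O)[nH]c2cc1N1CC(=O)N(c2ccccc2)C1=S)C1CCCCC1`, in this assay compound 2 gives 2990 nM
- compound 3, `Cc1nc2cc(N(C)C3CCCCC3)c(Nc3nc(-c4ccccc4)cs3)cc2[nH]c1=O`, in this assay compound 3 gives 12300 nM

Compound 3 stands at the highest of the three numbers. Its number and that of compound 1 lie within the scatter of each other, so nothing separates them; compound 2 stands beyond the scatter, with the lower number of the pair. No step between two compounds that differ in a single place has been recorded among these three.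

Compound 4, `CN(c1cc2nc(Cc3ccccc3)c(=O)[nH]c2cc1Nc1nc(-c2ccccc2)cs1)C1CCCCC1`, is not yet measured. Compared with compound 3 the change is phenyl in place of hydrogen on a saturated chain carbon bound to an aromatic carbon; cut one bond further out it reads methyl to benzyl. Within the data shown here, with no comparable step among the measured compounds, the expectation rests only on compound 3 and its value 12300 nM, and compound 4 is expected to move at most modestly toward a lower number, by the step of a 1.6-fold lower number from compound 3 to compound 4 (0.21 log units; within the scatter), a step that may not clear the scatter. Compound 4 is therefore estimated at 7500 nM, within a range from 2500 nM to 22000 nM.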

Compound 4, half-maximal inhibitory concentration: 42000 nM
Compound 4: the middle estimate sits 5.6-fold (0.75 log units) below what was measured, outside the stated range (above it).
By their numbers in this assay, from the lowest: compound 2; then compounds 1 and 3 (each within the scatter of the next); then compound 4.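

In this assay the change of phenyl in place of hydrogen on a saturated chain carbon bound to an aromatic carbon gives a 3.4-fold higher number from compound 3 to compound 4 (0.53 log units; beyond the scatter) and so moves the number toward weaker inhibition. Among these compounds, this is the first single-place step in the set, and it shows that this position is not silent in this read-out. Nothing at hand bears on why the number moves this way.

The compounds shown leave open whether the phenyl ring or simply the added chain carries the step, which an ethyl group or a longer chain at this place would separate. They also leave open how an amine or a carboxylic acid on that carbon would read.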